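Swapping the naphthyl arm for a fluorophenyl arm

A few compounds are considered here, and "the series" means these few. Any claim that something is new, unique, unknown or untested is made for them only; others in the source may bear on it.

Measured compounds:
compound 1 `c1ccc(-c2cn3ccnc3c(-c3ccc4ncn(C5CCCCC5)c4c3)n2)cc1` gives 55.2%
compound 2 `COc1ccc(-c2cn3ccnc3c(-c3ccc4ncn(C5CCCCC5)c4c3)n2)cc1` gives 61.5%
compound 3 `c1ccc2c(-c3cn4ccnc4c(-c4ccc5ncn(C6CCCCC6)c5c4)n3)cccc2c1` gives 23%

In a functional assay on UO-31 cells (Homo sapiens) for inhibition, read by sulforhodamine B assay, with a stated time of 48 h, tested at 10 uM (a lower number here means less inhibition, a higher number more inhibition at the concentration tested (going by the name of the read-out)), compound 3 stands lowest of the three numbers; the nearest is compound 1, higher by a number 32.2 percentage points lower from compound 1 to compound 3 (beyond the scatter) read in reverse, and the furthest is compound 2, higher by a number 38.5 percentage points lower from compound 2 to compound 3 (beyond the scatter) read in reverse. Compound 4 `Fc1ccc(-c2cn3ccnc3c(-c3ccc4ncn(C5CCCCC5)c4c3)n2)cc1` has not been measured. It differs from compound 3 by 4-fluorophenyl in place of naphthalen-1-yl on an aromatic carbon. Within the data shown here, two measured steps bear on this: a number 32.2 percentage points lower from compound 1 to compound 3 (beyond the scatter) and a number 38.5 percentage points lower from compound 2 to compound 3 (beyond the scatter), both large and both beyond the scatter, each replacing a single six-membered ring by naphthalen-1-yl and losing inhibition. The change to compound 4 runs the other way, back to a single ring, so a large rise is expected, roughly the size of those two steps. Compound 4 is therefore expected near 56%, with a range from 40% to 70%, a step of a number 33 percentage points higher from compound 3 to compound 4 (beyond the scatter).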

Compound 4, a percentage reported as inhibition, at one concentration (the size of the read-out at that concentration, not a potency): 37.8%
The estimate for compound 4 lay 18.2 percentage points above the measured number; measured number outside the range, below it.
By their numbers in this assay, from the lowest: compound 3; then compound 4; then compounds 1 and 2 (each within the scatter of the next).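

In this assay, a single ring at this position does not by itself recover inhibition: going back from naphthalen-1-yl to 4-fluorophenyl gives only a number 14.8 percentage points higher from compound 3 to compound 4 (beyond the scatter). What the ring carries also matters, since fluoro gives a number 17.4 percentage points lower from compound 1 to compound 4 (beyond the scatter) and, set against methoxy, a number 23.7 percentage points lower from compound 2 to compound 4 (beyond the scatter), whereas methoxy stayed within the scatter of hydrogen. No measurement shown here accounts for these steps. As far as these compounds go, whether a chlorine atom, an amine or a carboxylic acid in place of the fluoro would track compound 4 or compound 2 remains open.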